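Removing the Phenolic Hydroxy From a Trimethoxyphenyl Series

The compounds below may be only part of what the source reports. "The series", "measured", "known", "first", "only" and "open" are said of these compounds alone.

Measured so far in a functional assay on Ehrlich cells (Mus musculus) for cytotoxicity; a higher number here means a weaker inhibitor, a lower number a stronger inhibitor:
compound 1 `COc1cc(N2C(N)=C(C#N)C(c3c(O)ccc4ccccc34)C3=C2CC(C)(C)CC3=O)cc(OC)c1OC` gives 143000 nM;
compound 2 `COc1cc(N2C(N)=C(C#N)C(c3cccs3)C3=C2CC(C)(C)CC3=O)cc(OC)c1OC` gives "not active" (no number reported);
compound 3 `COc1cc(N2C(N)=C(C#N)C(c3ccc(O)cc3)C3=C2CC(C)(C)CC3=O)cc(OC)c1OC` gives 75800 nM.

Compound 3 stands level with compound 1 within the scatter, as the step of a 1.9-fold lower number from compound 1 to compound 3 (0.28 log units; within the scatter) shows, while compound 2 returned no number. Compound 4 `COc1cc(N2C(N)=C(C#N)C(c3ccccc3)C3=C2CC(C)(C)CC3=O)cc(OC)c1OC` carries the change (hydrogen in place of hydroxy on an aromatic carbon). Among the compounds with values here, no measured step touches a hydroxy on this aromatic ring; the one step on record, exchanging the whole aromatic group, stayed within the scatter, and the thiophene analogue compound 2 gave no number at all. Compound 4 is therefore expected to land near compound 3, with the step of a 1.3-fold higher number from compound 3 to compound 4 (0.12 log units; within the scatter) not beyond the scatter. The estimate for compound 4 in this assay is 100000 nM, within a range from 40000 nM to 300000 nM.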

Compound 4, half-maximal inhibitory concentration: "not active" (no number reported)
No number was reported for compound 4; the estimate stays without a comparison.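

Within the data shown here, compound 4 returned no number in this assay, so no step from compound 3 to compound 4 can be read. The compounds shown leave open what exchanging hydroxy for hydrogen does to the value. No evidence on hand bears on this result.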